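Shortening the chain between the core and the hydroxamic acid

A few compounds are considered here, and "the series" means these few. Any claim that something is new, unique, unknown or untested is made for them only; others in the source may bear on it.

Of the compounds shown here, three have been measured in an assay on cells for inhibition of protein deacetylase HDAC6 (Homo sapiens), read by fluorescence, with stated times of 15 min and 60 min; a lower number here means a stronger inhibitor, a higher number a weaker inhibitor. Compound 1, `O=C(CCCCNC(=O)c1cc(-c2ccc(F)cc2)[nH]n1)NO`, gives 275 nM and stands highest of the three. Compound 2, `Cc1ccc(-c2cc(C)n(Cc3ccc(C(=O)NO)cc3)n2)cc1`, gives 7 nM, and compound 3, `O=C(NO)c1ccc(CNC(=O)c2cc(-c3ccc(F)cc3)[nH]n2)cc1`, gives 1 nM; both sit well beyond the scatter from compound 1, with compound 3 the furthest away. No two of these three differ in only one place, so the gaps between them speak only as whole-molecule comparisons.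

Going by the values given here, compound 4, `O=C(CCNC(=O)c1cc(-c2ccc(F)cc2)[nH]n1)NO`, is the first close neighbour of compound 1. The difference is hydroxycarbamoyl in place of 2-(hydroxycarbamoyl)ethyl on a saturated chain carbon, two bonds along the chain from an amide-type nitrogen. The shared core and its aryl group are kept; only the chain that carries the hydroxamic acid is cut shorter.

Compound 1 already stands at the weak end of this small set, and the comparison compounds 2 and 3 both hold their hydroxamic acid on a longer spacer than compound 4 will. The author therefore expects compound 4 to be weaker than compound 1, with an estimated step of a 5.5-fold higher number from compound 1 to compound 4 (0.74 log units; beyond the scatter) in this assay. The estimate for compound 4 is 1500 nM, expected to lie between 300 nM and 8000 nM.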

Compound 4, half-maximal inhibitory concentration: > 5000 nM
Compound 4 gave a limit, no number (the forecaster's own chance of this, stated with the estimate: 15%); middle value at least 3.3-fold (0.52 log units) away from the limit.
By their numbers in this assay, from the lowest: compound 3; then compound 2; then compound 1. At a limit, above all of these: compound 4.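

In this assay compound 4 gives > 5000 nM, which is a limit of the assay and not a number. Going by these compounds alone, putting hydroxycarbamoyl in place of 2-(hydroxycarbamoyl)ethyl on this saturated chain carbon is the first change in one place in the set, and it brings an at least 18-fold higher number from compound 1 to compound 4 (1.25 log units; beyond the scatter), so at this position, with the shared core kept, the chain length alone moves the result well beyond the scatter. The step is bounded on one side only, and its true size stays unknown: the limit of > 5000 nM in this assay, at which 1 of the 4 values shown sits.

The compounds shown leave open how a longer chain than the 3-(hydroxycarbamoyl)propyl of compound 1 would read on the same core. They also leave open whether a carboxylic acid in place of the hydroxamic acid would keep any inhibition at either chain length.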